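The compounds below may be only part of what the source reports. "The series", "measured", "known", "first", "only" and "open" are said of these compounds alone.

In an assay on cells for inhibition of Voltage-dependent T-type calcium channel subunit alpha-1G (Homo sapiens), read by patch clamp, tested at 10 uM (on this read-out lower numbers stand for less inhibition and higher numbers for more inhibition at the one concentration tested (going by the name of the read-out)), two compounds have been measured so far. Compound 1, with the structure `O=C(CC1c2ccccc2N=C(SCCCCCN2CCCC2)N1c1ccccc1)NCc1ccc(F)cc1`, gives 60.1%. Compound 2, with the structure `CN(C)CCCCCSC1=Nc2ccccc2C(CC(=O)NCc2ccccc2)N1c1ccccc1`, gives 46.5%. Compound 2 therefore stands lowest of the two numbers, and its gap to compound 1 lies beyond the usual scatter of repeated measurements.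

Compound 3, with the structure `O=C(CC1c2ccccc2N=C(SCCCCCN2CCCC2)N1c1ccccc1)NCc1ccccc1`, has not yet been measured in this assay. It is reached from compound 2 by one change: pyrrolidin-1-yl in place of dimethylamino on a saturated chain carbon, five bonds along the chain from a sulfur. The chain between the sulfur and the amine stays the same length; only the group at its far end is exchanged.

Going by the values given here, no pair of measured compounds differs by exactly this change, so its effect is not known from a direct comparison. Compound 1 does carry the pyrrolidin-1-yl group and sits higher than compound 2, but compound 1 differs from compound 2 in more than one place, so that gap cannot be credited to this change alone.

The step from compound 2 to compound 3 is expected to be modestly upward, on the order of a number 8.5 percentage points higher from compound 2 to compound 3 (within the scatter). Compound 3 is accordingly estimated at 55%, with a range from 40% to 70%.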

Compound 3, a percentage reported as inhibition, at one concentration (the size of the read-out at that concentration, not a potency): 60.4%
Compound 3: middle estimate off by 5.4 percentage points, on the low side; measured number inside the range.
By their numbers in this assay, from the lowest: compound 2; then compounds 1 and 3 (each within the scatter of the next).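

In this assay, the exchange of dimethylamino for pyrrolidin-1-yl on a saturated chain carbon, five bonds along the chain from a sulfur, gives a number 13.9 percentage points higher from compound 2 to compound 3 (beyond the scatter), so the effect of this single change can now be read on its own. Hydrogen in place of fluoro on an aromatic carbon gives a number 0.3 percentage points higher from compound 1 to compound 3 (within the scatter), which means that, with pyrrolidin-1-yl at the end of the chain, the fluoro group brings no readable difference, and among these compounds only the amine exchange moves the number beyond the scatter. Nothing shown here explains why the amine exchange has this effect.

As far as these compounds go, each change rests on a single pair of compounds, so it remains open whether the fluoro group would also make no readable difference alongside dimethylamino. Also open, from the compounds shown here alone, is how other amines at the end of the chain, such as piperidin-1-yl, morpholin-4-yl or diethylamino, or a shorter or longer chain carrying pyrrolidin-1-yl, would compare with compound 3.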